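The source may report more compounds than this note shows. Statements on the series, on what has been measured and on what is new or still open speak of the compounds shown alone.

For the measured compounds named here, compound 3, with the structure `O=C1CCC(=O)N1C[C@H]1CN(c2ccc(-n3cc(-c4ccccn4)cn3)c(F)c2)C(=O)O1`, gives 1.58 in a physicochemical assay for lipophilicity, read by HPLC, measured as octanol-water partition (a lower number here means a more polar compound, a higher number a more lipophilic compound), which places it at the low end of the three numbers so far, within the scatter of compound 1 but clearly below compound 2. Compound 1 has the structure `O=C1O[C@@H](CO)CN1c1ccc(-n2cc(-c3ccccn3)cn2)c(F)c1` and gives 1.67; compound 2, with the structure `CN1CCN(C[C@H]2CN(c3ccc(-n4cc(-c5ccccn5)cn4)c(F)c3)C(=O)O2)CC1`, gives 2.2. The step to compound 4, whose structure is `CC(=O)OC[C@H]1CN(c2ccc(-n3cc(-c4ccccn4)cn3)c(F)c2)C(=O)O1`, is acetoxy in place of 2,5-dioxopyrrolidin-1-yl on a saturated chain carbon bound to a saturated ring carbon. The same position has been varied before: a number 0.09 log units lower from compound 1 to compound 3 (within the scatter), while a number 0.62 log units lower from compound 2 to compound 3 (beyond the scatter). Only the second of these moved the number beyond the scatter, and it involved a group quite unlike the acetoxy entering here. The incoming acetoxy and the leaving 2,5-dioxopyrrolidin-1-yl match in having no hydrogen-bond donors and two acceptors, so the change is expected to be small: the step from compound 3 to compound 4 is estimated as a number 0.17 log units higher from compound 3 to compound 4 (within the scatter), likely within the scatter or just above it. Compound 4 is therefore expected to give about 1.75, between 1.35 and 2.15.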

Compound 4, partition coefficient: 2.09
For compound 4 the middle estimate is 0.34 log units below the measured one; low and high end bracket the measured number.
By their numbers in this assay, from the lowest: compounds 3 and 1 (each within the scatter of the next); then compounds 4 and 2 (each within the scatter of the next).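

Matching counts of hydrogen-bond donors and acceptors did not make this a quiet swap: in this assay, acetoxy in place of 2,5-dioxopyrrolidin-1-yl gives a number 0.51 log units higher from compound 3 to compound 4 (beyond the scatter) at this position on a saturated chain carbon. Until now, only the 4-methylpiperazin-1-yl group stood apart here, but a number 0.11 log units lower from compound 2 to compound 4 (within the scatter) shows that acetoxy, which has no ring, cannot be told apart from it in this assay. Acetyl in place of hydrogen on the oxygen of compound 1 gives a number 0.42 log units higher from compound 1 to compound 4 (beyond the scatter), so this small change to the hydroxy group is enough to separate the two compounds.

On these data alone, whether a longer chain, such as propanoyloxy, or a simple amine, such as dimethylamino, would follow compound 4 or compound 3 remains open. Nothing measured here explains these steps.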